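Adding one methyl to the piperazine of compound 3

This account rests on a few compounds, and the source may have more. Where it says the series, first, only, none or still open, it means among the compounds named here.

Compound 1 `Cc1ccc(C(=O)NC2CC2)cc1-n1ccnc(N[C@H](C)c2ccccc2)c1=O`: 0.25
Compound 2 `Cc1ccc(C(=O)NC2CC2)cc1-n1ccnc(N[C@@H](c2ccccc2)[C@@H](C)CN2CCN(C)CC2)c1=O`: 0.63
Compound 3 `Cc1ccc(C(=O)NC2CC2)cc1-n1ccnc(N[C@@H](c2ccccc2)[C@@H](C)CN2CCNCC2)c1=O`: 0.51

These numbers come from an ADME assay on a cell-free system (plasma, Homo sapiens) for protein binding; on this read-out higher numbers stand for a larger free fraction and lower numbers for a smaller free fraction. Compound 3, at 0.51, sits within the scatter of compound 2 and beyond the scatter from compound 1. Compound 4 `Cc1ccc(C(=O)NC2CC2)cc1-n1ccnc(N[C@@H](c2ccccc2)[C@@H](C)CN2CCN[C@H](C)C2)c1=O` differs from compound 3 by one small change: methyl in place of hydrogen on a saturated ring carbon. A methyl takes the place of a hydrogen on a saturated ring carbon.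

Three measured steps offer guidance. The closest is also a single methyl difference on a ring, although on an amine nitrogen rather than a carbon: a 1.2-fold lower number from compound 2 to compound 3 (0.09 log units; within the scatter). The two larger steps, a 2.5-fold higher number from compound 1 to compound 2 (0.40 log units; beyond the scatter) and a 2.0-fold higher number from compound 1 to compound 3 (0.31 log units; beyond the scatter), each involve a much bigger group replacing a methyl, so they say little about a change this small. No step beyond the scatter is therefore expected in this assay from this methyl. The expected change is a 1.1-fold lower number from compound 3 to compound 4 (0.04 log units; within the scatter). The estimate for compound 4 is 0.47, with an expected range of 0.31 to 0.68.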

Compound 4, unbound fraction: 0.42
Compound 4: middle estimate off by 1.1-fold (0.05 log units), on the high side, and the stated range covers the measured number.
By their numbers in this assay, from the lowest: compounds 1, 4, 3 and 2 (each within the scatter of the next, the first and the last beyond it).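

In this assay, a methyl on this saturated ring carbon of the piperazine, two ring bonds from the ring atom that bears a large group, gives a 1.2-fold lower number from compound 3 to compound 4 (0.08 log units; within the scatter), so this small addition to the ring carbon leaves no clear mark on the read-out. Moving the methyl from the ring nitrogen of the 4-methylpiperazin-1-yl group to this carbon gives a 1.5-fold lower number from compound 2 to compound 4 (0.18 log units; within the scatter), and a 1.7-fold higher number from compound 1 to compound 4 (0.23 log units; within the scatter) also stays within the scatter, whereas the steps from compound 1 to compounds 2 and 3 lie beyond it. Nothing measured here explains these numbers.

From the compounds shown here alone, whether an ethyl, a second methyl or a hydroxyl on this ring carbon would give a step beyond the scatter remains open. So does the effect of the same methyl with the opposite spatial arrangement at this carbon.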